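A few compounds are considered here, and "the series" means these few. Any claim that something is new, unique, unknown or untested is made for them only; others in the source may bear on it.

Compound 1 `COc1cc(C(O)c2ccc3c(ccn3C)c2)cc(OC)c1OC` and compound 2 `CCn1ccc2cc(C(O)c3cc(OC)c(OC)c(OC)c3)ccc21` share one core and differ in a single place: methyl in place of hydrogen on a saturated chain carbon bound to an aromatic nitrogen. In a functional assay on HL-60 cells (Homo sapiens) for cytotoxicity, read by XTT assay, with a stated time of 72 h (on this read-out lower numbers stand for stronger inhibition and higher numbers for weaker inhibition), compound 1 gives > 10000 nM, which is a limit of the measurement rather than a number. In this assay compound 2 gives > 10000 nM, also a limit. The step that the two limits leave unreadable from compound 1 to compound 2 therefore cannot be sized, since both values sit at the limit of > 10000 nM in this assay, at which 3 of the 3 values shown sit. Compound 3 `COc1cc(/C(=N/OC(C)=O)c2ccc3c(ccn3C)c2)cc(OC)c1OC` carries a different core; how it differs from compound 1 is not broken down here. In this assay compound 3 gives > 10000 nM, again a limit. Compound 4 `CCn1ccc2cc(/C(=N\OC(C)=O)c3cc(OC)c(OC)c(OC)c3)ccc21` is not yet measured and differs from compound 3 by methyl in place of hydrogen on a saturated chain carbon bound to an aromatic nitrogen, the same change as from compound 1 to compound 2. Going by the values given here, the step that the limit leaves unreadable from compound 3 to compound 4 is expected to be small, as the one measured example of this change is unreadable. Compound 4 is expected to give 20000 nM, most likely again only a limit.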

Compound 4, half-maximal inhibitory concentration: > 1000 nM
Compound 4: only a limit was reported (the forecaster's own chance of this, stated with the estimate: 85%); the middle value lies beyond the limit too.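

Compound 3 and compound 4 both give only limits, not numbers, and the step between them cannot be read. The compounds shown leave open whether methyl in place of hydrogen on a saturated chain carbon bound to an aromatic nitrogen changes potency at all in this assay.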